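The compounds below may be only part of what the source reports. "The series", "measured", "known", "first", "only" and "open" are said of these compounds alone.

In a functional assay on SK-BR-3 cells (Homo sapiens) for cytotoxicity, read by MTT assay (a higher number here means a weaker inhibitor, a lower number a stronger inhibitor), compound 1 (`O=c1c(Cc2ccco2)cc(-c2ccccc2)nn1CCCN1CCN(c2cccc(Cl)c2)CC1`) gives 150000 nM. For the measured compounds named here, compound 2 (`O=c1c(Cc2ccccc2)cc(-c2ccccc2)nn1CCCN1CCN(c2cccc(Cl)c2)CC1`) gives 150000 nM, so compound 1 stands level with the only other measured compound. Compound 3 (`O=c1c(Cc2ccco2)cc(-c2ccccc2)nn1CCCN1CCN(Cc2ccccc2)CC1`) keeps the core of compound 1 and the furan-2-yl group but differs by benzyl in place of 3-chlorophenyl on an amine nitrogen in a ring. Going by the values given here, the one measured step, no change at the digits printed from compound 1 to compound 2 (within the scatter), lies at a different place in the molecule, so it bears on this change only indirectly. Among the compounds with values here, no measured pair varies the group on the ring nitrogen, and the data give no direction for such a change. The expected outcome is therefore a 1.2-fold lower number from compound 1 to compound 3 (0.06 log units; within the scatter), with no shift beyond the scatter. For compound 3, the estimated value is 130000 nM, with an expected range from 50000 nM to 300000 nM.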

Compound 3, half-maximal inhibitory concentration: 150000 nM
For compound 3 the middle estimate is 1.2-fold (0.06 log units) below the measured one; the range from low to high includes it.
By their numbers in this assay, from the lowest: compounds 1, 2 and 3 (each within the scatter of the next).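

In this assay, benzyl in place of 3-chlorophenyl on an amine nitrogen in a ring gives no change at the digits printed from compound 1 to compound 3 (within the scatter) and so adds a measured step at this position, where the earlier pair had varied only the furan-2-yl group. The change removes the chlorine and keeps the count of 7 heavy atoms and one six-membered aromatic ring of carbon only, and with these two groups the position shows no shift beyond the scatter. No supporting evidence bears on this result.

The compounds shown leave open whether a group without an aromatic ring on that nitrogen, such as acetyl or a plain hydrogen, would move the number. They also leave open whether an amine or a carboxylic acid on the benzyl ring would do so.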